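Notes on the step from compound 3 to compound 4

The source may hold more compounds than are shown below. What is called first, only, known or untested is meant among the compounds shown, and "the series" means these compounds.

Three compounds of the series have numbers in an ADME assay on cells for inhibition of cytochrome P450 11B1, mitochondrial (Homo sapiens), read by HPLC, with a stated time of 60 min; on this read-out lower numbers stand for stronger inhibition and higher numbers for weaker inhibition. Compound 1 `Fc1ccc2nc(-c3cncs3)n(C3CC3)c2c1` gives 4520 nM. Compound 3 `CCc1ncncc1-c1nc2cc(F)c(F)cc2n1C1CC1` gives 3330 nM; its number and that of compound 1 lie within the scatter of each other. Compound 2 `Fc1ccc2nc(-c3cnccn3)n(C3CC3)c2c1` reaches only a limit of the assay, > 10000 nM, which is the limit of > 10000 nM in this assay, at which 1 of the 3 values shown sits. For the measured compounds named here, the one step measured between neighbours is an at least 2.2-fold higher number from compound 1 to compound 2 (0.34 log units; beyond the scatter), a swap of the aromatic ring carried on the shared core.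

Compound 4 `Fc1cc2nc(-c3cncnc3NCCC(F)(F)F)n(C3CC3)c2cc1F` is not yet measured. It differs from compound 3 by (3,3,3-trifluoropropyl)amino in place of ethyl on an aromatic carbon. Going by the values given here, the measured step from compound 1 to compound 2 concerns a different place on the shared core and a different kind of change, so no measured step directly informs the present one; the only guide is that compound 3 and compound 1 sit close together while compound 2 reaches a limit.

With that thin basis, compound 4 is expected to stay near compound 3, the estimated step being a 1.3-fold lower number from compound 3 to compound 4 (0.12 log units; within the scatter). The estimate for compound 4 in this assay is 2500 nM, with a range from 800 nM to 8000 nM.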

Compound 4, half-maximal inhibitory concentration: 378 nM
Estimate against measurement, compound 4: 6.6-fold (0.82 log units) above, outside the stated range (below it).
By their numbers in this assay, from the lowest: compound 4; then compounds 3 and 1 (each within the scatter of the next). At a limit, above all of these: compound 2.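

In this assay, this place on the six-membered aromatic ring with 2 nitrogen turns out to respond strongly to its substituent: (3,3,3-trifluoropropyl)amino in place of ethyl gives an 8.8-fold lower number from compound 3 to compound 4 (0.94 log units; beyond the scatter). For the compounds shown here, the only earlier step, an at least 2.2-fold higher number from compound 1 to compound 2 (0.34 log units; beyond the scatter), ran towards a higher number and came from swapping the aromatic ring itself, so this is the first measured step towards a lower number, and it shows that a group of 7 heavy atoms is accepted here in place of one of 2. No measured property among the compounds shown bears on the cause of this step.

From the compounds shown here alone, the step changes the linking atom, the chain length and the terminal fluorines all at once, so the share of each stays open; a plain propylamino group, an ethylamino group, a longer fluorinated chain or a methoxy group at this place would help separate them. Going by these compounds, it also stays open whether (3,3,3-trifluoropropyl)amino gives a step of similar size on a core carrying a single fluorine, as the cores of compound 1 and compound 2 do.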